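Swapping Chloro for Methoxy on a Shared Core

The compounds below may be only part of what the source reports. "The series", "measured", "known", "first", "only" and "open" are said of these compounds alone.

Four compounds share one core and differ at two places: the group on the aryl amine ring and the pattern of the ketone ring. Compound 1 `COc1ccc(Nc2nc(N)c(C(=O)c3ccccc3)s2)cc1` carries a methoxy on the amine ring and a plain phenyl ketone; in a functional assay on CCRF-CEM cells (Homo sapiens) for antiproliferative activity, read by cell counting, with a stated time of 2 days (on this read-out higher numbers stand for weaker inhibition and lower numbers for stronger inhibition), compound 1 gives 300 nM. Compound 2 `Nc1nc(Nc2ccc(Cl)cc2)sc1C(=O)c1ccccc1` carries a chloro instead. In this assay compound 2 reaches only > 10000 nM, which is a limit and not a number, namely (the limit of > 10000 nM in this assay, at which 1 of the 3 values shown sits). The step of an at least 33-fold lower number from compound 2 to compound 1 (1.52 log units; beyond the scatter) corresponds to methoxy in place of chloro on an aromatic carbon.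

Compound 3 `COc1cc(C(=O)c2sc(Nc3ccc(Cl)cc3)nc2N)cc(OC)c1OC` keeps the chloro but has three methoxy groups on the ketone ring; the difference between the core of compound 2 and the core of compound 3 is not broken down here. In this assay compound 3 gives 190 nM, which lies within the scatter of the value of compound 1.

Compound 4 `COc1ccc(Nc2nc(N)c(C(=O)c3cc(OC)c(OC)c(OC)c3)s2)cc1` has not been measured. It differs from compound 3 by methoxy in place of chloro on an aromatic carbon, the same change as from compound 2 to compound 1, at the same place. The expected step of a 2.7-fold lower number from compound 3 to compound 4 (0.43 log units; beyond the scatter) is taken to be smaller than the measured one, since compound 3 starts from 190 nM, a number rather than a limit, leaving less room for a large move. Compound 4 is estimated at 70 nM, with a range from 15 nM to 300 nM.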

Compound 4, half-maximal inhibitory concentration: 1100 nM
For compound 4 the middle estimate is 16-fold (1.20 log units) below the measured one; the measured number lies above the stated range.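

In this assay, the swap of chloro for methoxy on the amine ring does not carry over from one core to the other: with three methoxy groups on the ketone ring it gives a 5.8-fold higher number from compound 3 to compound 4 (0.76 log units; beyond the scatter), whereas with a plain phenyl ketone the same swap moved the number the opposite way: the same change on two cores in this assay, an at least 33-fold lower number (1.52 log units; beyond the scatter) from compound 2 to compound 1 and a 5.8-fold higher number (0.76 log units; beyond the scatter) from compound 3 to compound 4, at least 190-fold (2.28 log units) apart, beyond the scatter of two such steps

Within these four compounds, then, the outcome of the swap depends on the ketone ring, but the data give no reason for this, and a single pair on each core cannot tell how general the reversal is. Going by these compounds, for compound 2 the read-out is > 10000 nM, a limit of the assay and not a number, and the true size of the earlier step stays unknown.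

The compounds shown carry only chloro or methoxy on the amine ring, and only a plain phenyl or a ketone ring with three methoxy groups. A fluoro, a methyl or an amine in that place on the amine ring, or a ketone ring with fewer methoxy groups, could show whether the reversal belongs to methoxy alone and how much of the ketone ring pattern it needs.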